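This account rests on a few compounds, and the source may have more. Where it says the series, first, only, none or still open, it means among the compounds named here.

Measured in an assay on CHO cells with metabotropic glutamate receptor 2 (Homo sapiens) as the target, read by FLIPR; on this read-out higher numbers stand for an effect only at larger amounts of compound and lower numbers for an effect already at smaller amounts:
- compound 1, `CCCn1c(CN2CCN(c3ncc(Cl)cn3)CC2)nc2ccccc21`: 794 nM
- compound 2, `Cn1c(CN2CCN(c3ccc(C(F)(F)F)cn3)CC2)nc2ccccc21`: 501 nM
- compound 3, `Cn1c(CN2CCC(c3ccccn3)CC2)nc2ccccc21`: > 3160 nM (a limit of this assay, not a number)

Compound 1 holds the higher of the two numbers obtained in this assay, but the gap to compound 2 lies within the usual scatter, so the two cannot be ranked. For compound 3 the result in this assay is only a limit (the limit of > 3160 nM in this assay, at which 1 of the 3 values shown sits).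

The next compound is compound 4, `Clc1cnc(N2CCN(Cc3nc4ccccc4n3Cc3ccccc3)CC2)nc1`. It differs from compound 1 by phenyl in place of ethyl on a saturated chain carbon bound to an aromatic nitrogen. Among the compounds with values here, no pair among the measured compounds isolates this change; compound 2 and compound 3 differ from compound 1 in other places as well, so the series gives no direct reading of its effect in this assay.

The step is expected to read a 1.3-fold lower number from compound 1 to compound 4 (0.10 log units; within the scatter), with no direction beyond the scatter asserted. Compound 4 is estimated at 630 nM in this assay, with a plausible range from 160 nM to 2500 nM.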

Compound 4, half-maximal effective concentration: 126 nM
The estimate for compound 4 lay 5.0-fold (0.70 log units) above the measured number, and the stated range ends above it.
By their numbers in this assay, from the lowest: compound 4; then compounds 2 and 1 (each within the scatter of the next). At a limit, above all of these: compound 3.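

In this assay, within the data shown here, propyl to benzyl on the saturated chain carbon bound to an aromatic nitrogen gives a 6.3-fold lower number from compound 1 to compound 4 (0.80 log units; beyond the scatter), the first direct reading at this position, since compound 2 and compound 3 differ from compound 1 in other places as well. The position therefore tolerates a six-membered aromatic ring of carbon only on this chain carbon, and the step lies beyond the scatter. Nothing measured on these compounds accounts for the step.

A single pair cannot separate the aromatic ring from the added carbons: a cyclohexylmethyl or a pyridylmethyl group in the same place would bear on that. From the compounds shown here alone, whether the step carries over to the other end group of compound 2 also remains open.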